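The source may report more compounds than this note shows. Statements on the series, on what has been measured and on what is new or still open speak of the compounds shown alone.

Measured so far:
- compound 1 `COc1cc(/C=C/C(=O)/C=C/c2nc3ccccc3n2C)ccc1O` gives 7000 nM
- compound 2 `COc1cc(/C=C/C(=O)/C=C/c2nc3cc(C)ccc3n2C)ccc1O` gives 7700 nM

In a functional assay on NCI-H460 cells (Homo sapiens) for cytotoxicity, read by MTT assay, with a stated time of 48 h (a higher number here means a weaker inhibitor, a lower number a stronger inhibitor), compound 2 stands level with compound 1 at 7000 nM, with no gap beyond the scatter. Compound 3 `COc1cc(/C=C/C(=O)/C=C/c2nc3c(C)cccc3n2C)ccc1O` is still unmeasured and differs from compound 1 as follows: methyl in place of hydrogen on an aromatic carbon. For the measured compounds named here, the only measured step that bears on this is the same replacement on a different aromatic carbon, a 1.1-fold higher number from compound 1 to compound 2 (0.04 log units; within the scatter), so no step beyond the scatter is expected in this assay. The expected step is a 1.1-fold higher number from compound 1 to compound 3 (0.06 log units; within the scatter). For compound 3 the estimated value is 8000 nM, with an expected range from 3500 nM to 18000 nM.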

Compound 3, half-maximal inhibitory concentration: 3000 nM
Estimate against measurement, compound 3: 2.7-fold (0.43 log units) above; measured number outside the range, below it.
By their numbers in this assay, from the lowest: compound 3; then compounds 1 and 2 (each within the scatter of the next).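

In this assay, methyl in place of hydrogen on this aromatic carbon, ortho to a fused ring and meta to a fused ring, gives a 2.3-fold lower number from compound 1 to compound 3 (0.37 log units; beyond the scatter), a modest step. The same replacement on a different aromatic carbon gives a 1.1-fold higher number from compound 1 to compound 2 (0.04 log units; within the scatter), so among these compounds the outcome of adding methyl depends on where it sits on the ring. Nothing available here accounts for this difference. Going by these compounds, whether a longer chain, an amine or a carboxylic acid on this same carbon would extend the step or reverse it remains open.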